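This account rests on a few compounds, and the source may have more. Where it says the series, first, only, none or still open, it means among the compounds named here.

Three compounds have so far been measured in a functional assay on A-375 cells (Homo sapiens) for antiproliferative activity, read by MTT assay, with a stated time of 24 h, tested at 0.02 ug/mL; on this read-out lower numbers stand for a weaker effect and higher numbers for a stronger effect at the one concentration tested:

Compound 1, `Cc1c(C(=O)Nc2c(F)cc(-c3cccc(F)c3)cc2F)nc2ccc(F)cc2c1O`, gives -0.13%.
Compound 2, `COc1ccc2nc(C(=O)Nc3ccc(-c4ccccc4)cc3)c(C)c(O)c2c1`, gives 0.56%.
Compound 3, `Cc1c(C(=O)Nc2c(F)cc(-c3cccc(F)c3)cc2F)nc2ccc(F)cc2c1C(=O)O`, gives -0.22%.

All three numbers lie within the usual scatter of one another, so none of them can be set apart from the rest. Compound 3 comes from compound 1 by one change, (carboxy in place of hydroxy on an aromatic carbon), and that change made a step of a number 0.1 percentage points lower from compound 1 to compound 3 (within the scatter) in this assay. Compound 2 differs from compound 1 in more than one place; the difference between the two cores is not broken down here.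

Compound 4, `COc1ccc2nc(C(=O)Nc3ccc(-c4ccccc4)cc3)c(C)c(C(=O)O)c2c1`, is not yet measured. Among the measured compounds shown here, it comes from compound 2 by carboxy in place of hydroxy on an aromatic carbon, which is the same change, at a place described in the same words, as the one that turned compound 1 into compound 3. The expected step from compound 2 to compound 4 is therefore a number 0.1 percentage points lower from compound 2 to compound 4 (within the scatter), set beside the earlier step, because the same change on compound 1 gave a number 0.1 percentage points lower from compound 1 to compound 3 (within the scatter). Compound 4 is thus estimated to give 0.5% in this assay, with a likely range from -6% to 7%.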

Compound 4, a percentage reported as inhibition, at one concentration (the size of the read-out at that concentration, not a potency): 0.68%
Compound 4: middle estimate off by 0.2 percentage points, on the low side; measured number inside the range.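

In this assay, carboxy in place of hydroxy on an aromatic carbon of compound 2 gave a number 0.1 percentage points higher from compound 2 to compound 4 (within the scatter). Set beside the earlier step, the same change on the two cores cannot be told apart: the same change on two cores in this assay, a number 0.1 percentage points lower (within the scatter) from compound 1 to compound 3 and a number 0.1 percentage points higher (within the scatter) from compound 2 to compound 4, 0.2 percentage points apart, within the scatter of two such steps. This shows that the change produced no step larger than the scatter on either core, but it does not show that a real effect carries from one core to the other, as neither step offers an effect to follow and all four numbers sit close to zero at the one concentration tested.

The compounds shown leave open whether a different group at this place, such as an amine or a nitrile, would move the read-out beyond the scatter. They also leave open whether hydroxy and carboxy would still match on these two cores under conditions where the compounds show a clear antiproliferative effect.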